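One phenyl group swapped, from compound 2 to compound 3

This account rests on a few compounds, and the source may have more. Where it says the series, first, only, none or still open, it means among the compounds named here.

In a functional assay on K562 cells (Homo sapiens) for cytotoxicity, read by MTT assay, with a stated time of 24 h (on this read-out higher numbers stand for weaker inhibition and lower numbers for stronger inhibition), compound 1 `COc1cc(/C=C2\CN(C)C/C(=C\c3ccc(C#N)cc3)C2=O)cc(OC)c1OC` gives 4290 nM. Compound 2 `CN1C/C(=C\c2ccc(Cl)cc2)C(=O)/C(=C/c2cccc([N+](=O)[O-])c2)C1` gives no number, only a limit of the assay, > 20000 nM. From the compounds shown here alone, it therefore has no exact place on the scale, and its true value remains unknown.

Compound 3 `CN1C/C(=C\c2cccc(Br)c2)C(=O)/C(=C/c2cccc([N+](=O)[O-])c2)C1` keeps the rest of compound 2 but carries 3-bromophenyl in place of 4-chlorophenyl on a double-bonded chain carbon bound to a double-bonded ring carbon. Going by the values given here, no measured pair of compounds shows what such a swap does. In this assay the expected step is an at least 1.1-fold lower number from compound 2 to compound 3 (0.04 log units; that floor lies within the scatter), none beyond the scatter, with no direction favoured. Among the compounds with values here, this expectation rests on the single limit of compound 2, so it stays loose, and a further limit would be no surprise. For compound 3 the estimated value is 18000 nM, with an expected range from 6000 nM to 50000 nM.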

Compound 3, half-maximal inhibitory concentration: 12200 nM
Estimate against measurement, compound 3: 1.5-fold (0.17 log units) above; the range from low to high includes it.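

With this swap, compound 3 gives an exact reading of 12200 nM in this assay, so the series now has a number at this position with the 3-nitrophenyl-free comparison set aside.

In this assay, compound 3 brings this position onto the measured scale with an exact value of 12200 nM. Replacing 4-chlorophenyl with 3-bromophenyl on a double-bonded chain carbon bound to a double-bonded ring carbon gives an at least 1.6-fold lower number from compound 2 to compound 3 (0.21 log units; that floor lies within the scatter), so the change need not amount to more than the usual scatter. Compound 2 has only a limit, and the step can be stated only as a floor resting on it: the limit of > 20000 nM in this assay, at which 1 of the 3 values shown sits.

The swap changes both the halogen and its place on the phenyl ring, so the compounds shown cannot separate the contribution of bromine from that of its position; 3-chlorophenyl or 4-bromophenyl would divide the two. They also leave open how an aminophenyl or a carboxyphenyl group would read at this position.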